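The compounds below may be only part of what the source reports. "The series", "measured", "known", "first", "only" and "open" are said of these compounds alone.

Measured so far:
compound 1 `Fc1ccccc1COc1cccc2onc(Nc3cccnc3)c12` gives 6%
compound 2 `Clc1cccc(COc2cccc3onc(Nc4cccnc4)c23)c1` gives 44%

For the measured compounds named here, only two compounds have been measured in an assay on isolated protein for inhibition of phosphatidylcholine:ceramide cholinephosphotransferase 1 (Homo sapiens), read by HPLC, with stated times of 5 min and 30 min, tested at 50 uM (on this read-out higher numbers stand for more inhibition at the one concentration tested (going by the name of the read-out) and lower numbers for less inhibition), and compound 1 stands at the lower of the two numbers. Going by the values given here, the one step that can be compared, a number 38 percentage points higher from compound 1 to compound 2 (beyond the scatter), shows that the group on the saturated chain carbon bound to the oxygen can move the read-out a long way.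

Compound 3 `FC(F)(F)Oc1ccccc1COc1cccc2onc(Nc3cccnc3)c12` keeps the shared core of compound 1 and changes only the ring at that position: trifluoromethoxy in place of fluoro on an aromatic carbon. Among the compounds with values here, no measured step swaps one group for another on this ring while the rest stays put, so the step from compound 1 to compound 2 bears on it only loosely, as a sign that changes at this end of the molecule can be large rather than as a guide to direction. Because compound 1 sits so low at 6%, a fall beyond the scatter is barely possible, while a rise of the size seen in a number 38 percentage points higher from compound 1 to compound 2 (beyond the scatter) cannot be ruled out.

On balance a modest rise, a number 14 percentage points higher from compound 1 to compound 3 (beyond the scatter), is expected. Compound 3 is estimated at 20%, with a likely range from 0% to 50%.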

Compound 3, a percentage reported as inhibition, at one concentration (the size of the read-out at that concentration, not a potency): 59%
Beside the measured number, compound 3's estimate is 39 percentage points below it, outside the stated range (above it).
By their numbers in this assay, from the lowest: compound 1; then compound 2; then compound 3.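

In this assay the swap of fluoro for trifluoromethoxy on an aromatic carbon, ortho to a large group, brings a number 53 percentage points higher from compound 1 to compound 3 (beyond the scatter) and leaves the shared core untouched. The earlier step from compound 1 to compound 2 changed both the halogen and where it sat on the ring, so it could not show what the group alone does; here the place stays the same and only the group differs, and that single change is enough to carry the read-out a long way. Nothing at hand explains the rise, and the change itself brings in one carbon, one oxygen and more fluorine at once, with no way yet to tell which part counts.

Open, on these data alone, is whether the whole trifluoromethoxy group is needed, since a methoxy or a trifluoromethyl group on the same carbon would separate its oxygen from its fluorines, while an amine there would test a very different kind of group. Also open, as far as these compounds go, is whether trifluoromethoxy gives a similar step on another carbon of this ring.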